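The compounds below may be only part of what the source reports. "The series", "measured", "known", "first", "only" and "open" are said of these compounds alone.

Measured so far:
Compound 1 `COc1ccc(C2C(C(=O)Nc3ccc(Cl)cc3)=C(C)NC(C)=C2C(=O)Nc2ccc(Cl)cc2)cc1` — 20 ug/mL
Compound 2 `CC1=C(C(=O)Nc2ccc(Cl)cc2)C(c2ccco2)C(C(=O)Nc2ccc(Cl)cc2)=C(C)N1` — 24 ug/mL
Compound 3 `CC1=C(C(=O)Nc2ccc(Cl)cc2)CC(C(=O)Nc2ccc(Cl)cc2)=C(C)N1` — 40 ug/mL

In an ADME assay on Vero cells (Chlorocebus sabaeus) for cytotoxicity, read by sulforhodamine B assay, with a stated time of 3 days (a lower number here means that less compound is tolerated, a higher number that more compound is tolerated), compound 2 gives 24 ug/mL, and this number lies within the scatter of both other compounds: one of the two steps that reach it is a 1.2-fold higher number from compound 1 to compound 2 (0.08 log units; within the scatter), and the other is a 1.7-fold higher number from compound 2 to compound 3 (0.22 log units; within the scatter). The shared core carries a saturated ring carbon whose substituent is the only point of variation among these three compounds, and the three numbers together do not separate from one another beyond the scatter.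

Compound 4 `CC1=C(C(=O)Nc2ccc(Cl)cc2)C(c2ccccc2O)C(C(=O)Nc2ccc(Cl)cc2)=C(C)N1` differs from compound 2 in this one place: 2-hydroxyphenyl in place of furan-2-yl on a saturated ring carbon. The measured steps that touch this position are the exchange of 4-methoxyphenyl for furan-2-yl, a 1.2-fold higher number from compound 1 to compound 2 (0.08 log units; within the scatter), and the two exchanges for hydrogen, a 2.0-fold higher number from compound 1 to compound 3 (0.30 log units; within the scatter) and a 1.7-fold higher number from compound 2 to compound 3 (0.22 log units; within the scatter). Among the measured compounds shown here, all three remained within the scatter, and none of them involved a 2-hydroxyphenyl group, so the new substituent has no direct precedent here. Since aryl groups at this carbon gave numbers close to each other in compound 1 and compound 2, a step of no more than the scatter is expected in this assay for compound 4 as well, with no clear direction.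

For compound 4 the expected value in this assay is 22 ug/mL, with a range from 11 ug/mL to 45 ug/mL. This estimate means a step of a 1.1-fold lower number from compound 2 to compound 4 (0.04 log units; within the scatter) from compound 2 to compound 4.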

Compound 4, half-maximal cytotoxic concentration: 62 ug/mL
Beside the measured number, compound 4's estimate is 2.8-fold (0.45 log units) below it; the whole stated range lies below it.
By their numbers in this assay, from the lowest: compounds 1, 2, 3 and 4 (each within the scatter of the next, the first and the last beyond it).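

In this assay this saturated ring carbon now gives steps beyond the scatter, which no earlier exchange there had done: 2-hydroxyphenyl in place of furan-2-yl gives a 2.6-fold higher number from compound 2 to compound 4 (0.41 log units; beyond the scatter) and 2-hydroxyphenyl in place of 4-methoxyphenyl gives a 3.1-fold higher number from compound 1 to compound 4 (0.49 log units; beyond the scatter), both of them modest. Against hydrogen on the same carbon the new group stays within the scatter, with a 1.6-fold higher number from compound 3 to compound 4 (0.19 log units; within the scatter) as the step that shows it. The aromatic groups at this position therefore do not all give the same number, which the close pair of compound 1 and compound 2 could not show, although the change remains small and the hydrogen compound is not separated from compound 4.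

Compound 4 differs from compound 2 in both its ring and its hydroxyl group, so the compounds shown do not tell these two apart: a plain phenyl group or a 2-aminophenyl group at this carbon would be needed to do so. Nothing available here bears on what lies behind the step.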